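The source may hold more compounds than are shown below. What is called first, only, known or untested is meant among the compounds shown, and "the series" means these compounds.

Working notes on the series. Compound 1 `C[C@@H]1CN(c2ccc(-c3n[nH]c4cnc(N5[C@H](C)CCC[C@@H]5C)nc34)cn2)CCN1` gives 384 nM in an assay on HeLa cells for inhibition of activin receptor type-1 (Homo sapiens), read by HTRF, with stated times of 1 h and 30 min; a lower number here means a stronger inhibitor, a higher number a weaker inhibitor. Its only comparator, compound 2 `C[C@@H]1CN(c2ccc(-c3n[nH]c4cnc(N5[C@H](C)CN(C(=O)N(C)C)C[C@@H]5C)nc34)cn2)CCN1`, gives 350 nM in this assay, and the two numbers lie within the scatter of each other, so neither stands apart. Compound 3 `C[C@@H]1CN(c2ccc(-c3n[nH]c4cnc(N5[C@H](C)COC[C@@H]5C)nc34)cn2)CCN1` differs from compound 1 by 3,5-dimethylmorpholin-4-yl in place of 2,6-dimethylpiperidin-1-yl on an aromatic carbon. Among the compounds with values here, no step between measured compounds informs this change, so the step from compound 1 to compound 3 is expected to be small, a 1.2-fold higher number from compound 1 to compound 3 (0.07 log units; within the scatter), and not clearly beyond the scatter in either direction. Compound 3 is therefore estimated at 450 nM, with a range from 180 nM to 1100 nM.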

Compound 3, half-maximal inhibitory concentration: 245 nM
Beside the measured number, compound 3's estimate is 1.8-fold (0.26 log units) above it, within the range that was stated.
By their numbers in this assay, from the lowest: compounds 3, 2 and 1 (each within the scatter of the next).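

Within the data shown here, at this position, on an aromatic carbon between two ring nitrogen atoms, 3,5-dimethylmorpholin-4-yl in place of 2,6-dimethylpiperidin-1-yl gives a 1.6-fold lower number from compound 1 to compound 3 (0.20 log units; within the scatter) in this assay and is the only step read here. The change of ring content therefore leaves the number in the same band, with no clear gain or loss. Nothing measured alongside these numbers bears on this result.

The compounds shown leave open whether unsubstituted morpholin-4-yl, or an open-chain amine such as dimethylamino, at this position would move the number beyond the scatter.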